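Swapping Methoxy for Chloro on the Pyridine of Compound 2

The compounds below may be only part of what the source reports. "The series", "measured", "known", "first", "only" and "open" are said of these compounds alone.

Among the compounds with values here, compound 2 `COc1ncc(-c2ccc3nccc(-c4ccc(Cn5cncn5)cc4)c3c2)cc1NS(=O)(=O)c1ccc(F)cc1F` gives 16 nM in a functional assay on A549 cells (Homo sapiens) for cytotoxicity, read by MTT assay, with a stated time of 72 h (on this read-out lower numbers stand for stronger inhibition and higher numbers for weaker inhibition), the lowest of the two numbers measured; compound 1 `COc1ncc(-c2ccc3nccc(-c4ccc(C)cc4)c3c2)cc1NS(=O)(=O)c1ccc(F)cc1F` gives 1240 nM, and the step of a 78-fold lower number from compound 1 to compound 2 (1.89 log units; beyond the scatter) is the only measured step. Compound 3 `O=S(=O)(Nc1cc(-c2ccc3nccc(-c4ccc(Cn5cncn5)cc4)c3c2)cnc1Cl)c1ccc(F)cc1F` differs from compound 2 by chloro in place of methoxy on an aromatic carbon. Within the data shown here, no measured step bears on this change, since the single step concerns a different position; compound 3 is therefore expected to show a step of a 1.6-fold higher number from compound 2 to compound 3 (0.19 log units; within the scatter), not beyond the scatter. Compound 3 is estimated at 25 nM, within 6 nM to 110 nM.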

Compound 3, half-maximal inhibitory concentration: 642 nM
Compound 3: middle estimate off by 26-fold (1.41 log units), on the low side, and the stated range ends below it.
By their numbers in this assay, from the lowest: compound 2; then compounds 3 and 1 (each within the scatter of the next).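

In this assay, chloro in place of methoxy on the aromatic carbon next to the ring nitrogen gives a 40-fold higher number from compound 2 to compound 3 (1.60 log units; beyond the scatter). This shows that the number is sensitive to the group at this position, ortho to a ((2,4-difluorophenyl)sulfonyl)amino group, which the earlier step, made at a different position, could not show. No evidence is available to explain this step.

From the compounds shown here alone, how an ethoxy group or an amine on this carbon would read remains open. So does whether the step would be the same size with the 1H-1,2,4-triazol-1-yl group absent.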